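Sulfonyl aryl variation on the shared chromenone core

The source may report more compounds than this note shows. Statements on the series, on what has been measured and on what is new or still open speak of the compounds shown alone.

Measured so far:
Compound 1 `COc1ccc(-c2c(I)c(=O)c3c(OC)cc(OC)cc3n2S(=O)(=O)c2ccc(OC)cc2)cc1` in a functional assay on SUP-B15 cells (Homo sapiens) for antiproliferative activity, with a stated time of 72 h (on this read-out higher numbers stand for an effect only at larger amounts of compound and lower numbers for an effect already at smaller amounts), gives 12300 nM.
Compound 2 `COc1ccc(-c2cc(=O)c3c(OC)cc(OC)cc3n2S(=O)(=O)c2ccc(C)c([N+](=O)[O-])c2)cc1` in this assay gives > 51700 nM; this is a limit of the assay, not a number.

Compound 2 thus stands at the ceiling of the numbers shown, one of the two values sitting there (the limit of > 51700 nM in this assay, at which 1 of the 2 values shown sits). Compound 1 differs from compound 2 in more than one place, so the two values are compared only as they stand: compound 1 gives a number, compound 2 only a limit.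

Compound 3 `COc1ccc(-c2cc(=O)c3c(OC)cc(OC)cc3n2S(=O)(=O)c2cc(F)c(F)c(F)c2)cc1` is not yet measured. It differs from compound 2 by 3,4,5-trifluorophenyl in place of 4-methyl-3-nitrophenyl on a sulfonyl sulfur. Among the measured compounds shown here, no single-change step between measured compounds is available, so the expected size of the step in this assay from compound 2 to compound 3 can only be set loosely; a move towards smaller amounts is expected, yet quite possibly not beyond the scatter, as an at least 1.7-fold lower number from compound 2 to compound 3 (0.23 log units; that floor lies within the scatter). Compound 3 is expected at 30000 nM, within 8000 nM to 100000 nM, with a real chance that only a limit is again reported.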

Compound 3, half-maximal effective concentration: > 65500 nM
Compound 3: no number, only a limit; the forecaster's own chance of this, stated with the estimate: 45%; middle value at least 2.1-fold (0.33 log units) from the limit.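

In this assay compound 3 gives > 65500 nM, a limit and not a number. Among the compounds shown here, compound 2 gives > 51700 nM, also a limit, so no step between compound 2 and compound 3 can be read. Going by these compounds, how 3,4,5-trifluorophenyl and 4-methyl-3-nitrophenyl on a sulfonyl sulfur compare in this assay remains open.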